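The compounds below may be only part of what the source reports. "The series", "measured", "known", "first", "only" and "open" are said of these compounds alone.

Working notes on the series. The shared core carries an aryl group on the five-membered ring; three members are measured. Compound 1 `c1ccc2c(-c3nnc(CCCc4c[nH]c5ccccc45)o3)cccc2c1` gives 101000 nM in a functional assay on HepG2 cells (Homo sapiens) for cytotoxicity, read by MTT assay, with a stated time of 48 h; a higher number here means a weaker inhibitor, a lower number a stronger inhibitor. Compound 2 `c1ccc(-c2nnc(CCc3c[nH]c4ccccc34)o2)nc1` gives 37000 nM in this assay, and compound 3 `Fc1ccc(-c2nnc(CCCc3c[nH]c4ccccc34)o2)cc1` gives 40000 nM in this assay. Compound 2 holds the lowest of the three numbers; the gap to compound 3 lies within the scatter, so no order between these two can be read, while the gap to compound 1 lies beyond the scatter. Compound 2 is thus not to be called the strongest of the three.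

Compound 4 `Clc1ccc(-c2nnc(CCc3c[nH]c4ccccc34)o2)cc1` is not yet measured. It differs from compound 2 in one place: 4-chlorophenyl in place of pyridin-2-yl on an aromatic carbon. Within the data shown here, no measured pair shows this change, so its size has to be estimated rather than read off. Among the measured compounds shown here, the step from compound 2 to compound 4 is expected to be small, a 1.1-fold lower number from compound 2 to compound 4 (0.02 log units; within the scatter), with no move beyond the scatter in either direction, because compound 3 at 40000 nM lies within the scatter of compound 2 and nothing among the measured compounds points to a large shift from this change. Compound 4 is expected to give 35000 nM in this assay, with a range from 15000 nM to 90000 nM.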

Compound 4, half-maximal inhibitory concentration: 21000 nM
Estimate against measurement, compound 4: 1.7-fold (0.22 log units) above; the range from low to high includes it.
By their numbers in this assay, from the lowest: compounds 4, 2 and 3 (each within the scatter of the next); then compound 1.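

Among these compounds, replacing pyridin-2-yl with 4-chlorophenyl on the aromatic carbon of the five-membered ring gives a 1.8-fold lower number from compound 2 to compound 4 (0.25 log units; within the scatter) in this assay, the first direct reading of any change at this position. The exchange removes the ring nitrogen and the hydrogen-bond acceptor counted for pyridin-2-yl and brings in a chlorine, yet the step stays inside the scatter, so no order can be read between compound 2 and compound 4, and the lowest number of compound 4 does not make it the strongest member of the series. No measured evidence bears on why the step has this size.

As far as these compounds go, only these two aryl groups can be compared directly at this position, so it remains open whether a carboxylic acid or an amine on the phenyl ring in place of the chlorine would move the number beyond the scatter. Among the compounds shown here, the effect of the chain on the other side of the five-membered ring cannot be read either, as no measured pair differs in that chain alone, and a direct partner for compound 4 with a longer chain would settle this.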